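Shortening an Ester Chain

The source may report more compounds than this note shows. Statements on the series, on what has been measured and on what is new or still open speak of the compounds shown alone.

Measured compounds:
compound 1 `CCCCOC(=O)C1=C(S[C@@H]2CN[C@H](C(=O)Nc3cccc(C(=O)OCCCC)c3)C2)[C@H](C)[C@@H]2[C@@H]([C@@H](C)O)C(=O)N12`: "not determined" (no result reported)
compound 2 `CCOC(=O)C1=C(S[C@@H]2CN[C@H](C(=O)Nc3cccc(C(=O)OCC)c3)C2)[C@H](C)[C@@H]2[C@@H]([C@@H](C)OC(=O)CC)C(=O)N12`: 764 ng.h/mL
compound 3 `CCCOC(=O)C1=C(S[C@@H]2CN[C@H](C(=O)Nc3cccc(C(=O)OCCC)c3)C2)[C@H](C)[C@@H]2[C@@H]([C@@H](C)O)C(=O)N12`: "not determined" (no result reported)

In an ADME assay on the whole organism (plasma, strain Beagle) for pharmacokinetics, with Canis familiaris (Canis lupus familiaris) as the target, read by LC-MS, with a stated time of 8 h, at a dose of 10 mg/kg by the intraduodenal route (a lower number here means less compound in the circulation, a higher number more compound in the circulation at the dose given), compound 2 gives 764 ng.h/mL. Among the compounds with values here, compound 1 and compound 3 have no number in this assay, so compound 2 carries the only value shown and stands alone, with nothing to rank it against. Compound 4 `CCOC(=O)C1=C(S[C@@H]2CN[C@H](C(=O)Nc3cccc(C(=O)OCC)c3)C2)[C@H](C)[C@@H]2[C@@H]([C@@H](C)OC(C)=O)C(=O)N12` differs from compound 2 by hydrogen in place of methyl on a saturated chain carbon bound to a carbonyl carbon. Within the data shown here, no step between two measured compounds exists to show how a change of this kind moves the area under the curve. Given how small the change is, the expected step from compound 2 to compound 4 is a 1.1-fold lower number from compound 2 to compound 4 (0.04 log units; within the scatter), nothing beyond the usual scatter in either direction. Compound 4 is estimated to give 700 ng.h/mL, between 350 ng.h/mL and 1400 ng.h/mL.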

Compound 4, area under the concentration-time curve: 1030 ng.h/mL
The estimate for compound 4 lay 1.5-fold (0.17 log units) below the measured number; measured number inside the range.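

In this assay, within the data shown here, the change from propanoyloxy to acetoxy reads a 1.3-fold higher number from compound 2 to compound 4 (0.13 log units; within the scatter) and gives the first measured step at this position. The methyl on the saturated chain carbon bound to a carbonyl carbon can go without a measurable effect on the area under the curve, so the two compounds cannot be told apart here. Nothing available explains this result. From the compounds shown here alone, whether a longer chain such as butanoyl would behave the same remains open. So does the effect of an amine on that same chain carbon.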